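From compound 3 to compound 4: notes on the series

The compounds below may be only part of what the source reports. "The series", "measured", "known", "first", "only" and "open" are said of these compounds alone.

- Compound 1 `CC1=C(CC(=O)NCCN(C)C)c2cc(F)ccc2/C1=C\c1nc2ccccc2s1`: 3630 nM
- Compound 2 `CC1=C(CC(=O)NCCN2CCCC2)c2cc(F)ccc2/C1=C\c1ccncc1`: 7190 nM
- Compound 3 `CC1=C(CC(=O)N(C)CCN(C)C(=O)[C@@H](N)C(C)C)c2cc(F)ccc2/C1=C\c1ccc([S+](C)[O-])cc1`: > 50000 nM (a limit of the assay)

In a functional assay on MDA-MB-231 cells (Homo sapiens) for inhibition, read by CellTiter-Glo, with a stated time of 72 h (on this read-out higher numbers stand for lower toxicity in this test and lower numbers for higher toxicity in this test), compound 1 gives 3630 nM and compound 2 gives 7190 nM, two values within the usual scatter of each other. Compound 3 reads > 50000 nM, which is a limit of the assay and not a number.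

The next compound is compound 4 `CC1=C(CC(=O)N(C)CCN(C)S(=O)(=O)c2ccc(C)cc2)c2cc(F)ccc2/C1=C\c1ccc([S+](C)[O-])cc1`, which differs from compound 3 in one group: (4-methylphenyl)sulfonyl in place of (1-amino-2-methylpropyl)carbonyl on an amine nitrogen. In words, (4-methylphenyl)sulfonyl stands in place of (1-amino-2-methylpropyl)carbonyl on an amine nitrogen. Within the data shown here, no measured pair shows this change, so the step in this assay can only be expected. A modest move toward lower numbers is expected, or no readable move at all, with compound 4 possibly reported as a limit too. This direction rests only on compound 3 standing at > 50000 nM, which leaves room on one side alone. The expected change is an at least 2.0-fold lower number from compound 3 to compound 4 (0.30 log units; that floor lies within the scatter). For compound 4 the estimate is 25000 nM, with an expected range of 6000 nM to 50000 nM.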

Compound 4, half-maximal cytotoxic concentration: 17800 nM
Compound 4: middle estimate off by 1.4-fold (0.15 log units), on the high side, and the stated range covers the measured number.
By their numbers in this assay, from the lowest: compounds 1 and 2 (each within the scatter of the next); then compound 4. At a limit, above all of these: compound 3.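

In this assay, the amine nitrogen of the side chain proves to be a place where one group change registers: (4-methylphenyl)sulfonyl in place of (1-amino-2-methylpropyl)carbonyl gives an at least 2.8-fold lower number from compound 3 to compound 4 (0.44 log units; beyond the scatter). The change swaps a group with a hydrogen-bond donor, a defined stereocentre and no ring for one with a six-membered aromatic ring, no hydrogen-bond donor and no stereocentre, and compound 4 returns a number at this place, 17800 nM. Compound 3 remains a limit of the assay and not a number, so the step is bounded on one side only because of that limit: the limit of > 50000 nM in this assay, at which 1 of the 4 values shown sits.

Among these compounds, the single step changes the linking unit and the ring-bearing part together, and a methanesulfonyl or a benzoyl group on the same nitrogen would be needed to separate the sulfonyl link from the aromatic ring. The other steps among these compounds cannot be read, as compound 1 and compound 2 differ from compound 3 and compound 4 in more than one place, which leaves open how this side-chain change behaves alongside the other groups on the shared core.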